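The compounds below may be only part of what the source reports. "The series", "measured", "known", "first", "only" and "open" are said of these compounds alone.

Among the compounds with values here, in a functional assay on L929 cells (Mus musculus) for antiproliferative activity, read by MTT assay (on this read-out higher numbers stand for weaker inhibition and lower numbers for stronger inhibition), compound 1 `C=CCC[C@H]1CC(=O)[C@@H]2C=CC(=O)[C@H]12` gives 20000 nM and compound 2 `C[C@@H]1[C@H](O[Si](c2ccccc2)(c2ccccc2)C(C)(C)C)C[C@]2(C)CC3(C[C@]12C)OCC(C)(C)CO3` gives 11800 nM as the only numbers so far. These two values lie within the usual scatter of each other, so the data do not separate them, even though the two structures look very different. Compound 3 `C[C@H]1[C@H](O[Si](c2ccccc2)(c2ccccc2)C(C)(C)C)C[C@]2(C)CC3(C[C@]12C)OCC(C)(C)CO3` differs from compound 2 only in configuration as drawn (the two compounds have the same atoms and bonds and differ only in configuration as drawn: 1 of 4 stereo elements differ; a stereocentre at a saturated ring carbon is drawn S in compound 2 and R in compound 3): a stereocentre at a saturated ring carbon is drawn S in compound 2 and R in compound 3. Within the data shown here, nothing measured so far shows what such a change does here, so the only anchor is compound 2 at 11800 nM as the closest measured relative. The expected step of a 1.0-fold higher number from compound 2 to compound 3 (0.01 log units; within the scatter) stays within the scatter in this assay and has no favoured direction. Compound 3 is estimated at 12000 nM with an expected range from 5500 nM to 25000 nM on this read-out.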

Compound 3, half-maximal inhibitory concentration: 15800 nM
Beside the measured number, compound 3's estimate is 1.3-fold (0.12 log units) below it, and the stated range covers the measured number.
By their numbers in this assay, from the lowest: compounds 2, 3 and 1 (each within the scatter of the next).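

Within the data shown here, compounds 2 and 3 form the first pair here that can be compared directly, and the comparison concerns a single feature: the fact that compounds 2 and 3 differ only in the configuration as drawn. In this assay, the S and R drawings of this stereocentre at a saturated ring carbon are separated by a 1.3-fold higher number from compound 2 to compound 3 (0.13 log units; within the scatter), so the data do not tell the two configurations apart. With the rest of this structure held constant, the configuration at this carbon therefore has no effect that can be distinguished from the usual variation between repeated measurements.

Going by these compounds, it remains open whether this configuration would still make so little difference if the tert-butyldiphenylsilyl ether were replaced by a free hydroxyl or an amine. Compound 1 differs from both compounds in too many places for its value to add anything about this stereocentre.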